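A few compounds are considered here, and "the series" means these few. Any claim that something is new, unique, unknown or untested is made for them only; others in the source may bear on it.

Compound 1 `CC(C)Oc1ccc(-c2cc(C(=O)O)nn2-c2ccccc2)cc1` and compound 2 `CC(C)COc1ccc(-c2cc(C(=O)O)nn2-c2ccccc2)cc1` share one core and differ only in the group on an oxygen on an aromatic ring. In an assay for displacement of a labelled ligand from E3 ubiquitin-protein ligase Mdm2 (Homo sapiens), read by fluorescence polarization, with a stated time of 30 min (on this read-out lower numbers stand for stronger inhibition and higher numbers for weaker inhibition), compound 1 gives 2290 nM, and compound 2 gives 7420 nM. Going by the values given here, the one change between them, (isobutyl in place of isopropyl on an oxygen on an aromatic ring), made a step of a 3.2-fold higher number from compound 1 to compound 2 (0.51 log units; beyond the scatter).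

Compound 3 `CCOc1ccc(-c2c(NC(=O)c3ccc(OC(C)C)cc3)c(C(=O)O)nn2-c2ccc(Oc3ccccc3)cc2)cc1` is built on a larger core; how that core differs from the core of compound 1 is not broken down here. In this assay, among the compounds with values here, compound 3 gives 301 nM, the lowest of the three numbers measured so far.

Compound 4 `CCOc1ccc(-c2c(NC(=O)c3ccc(OCC(C)C)cc3)c(C(=O)O)nn2-c2ccc(Oc3ccccc3)cc2)cc1` has not yet been measured. It differs from compound 3 by isobutyl in place of isopropyl on an oxygen on an aromatic ring. Within the data shown here, this is the same change as the one between compound 1 and compound 2, made at the same kind of place in both pairs, so the earlier step is the only guide available for it.

From compound 3 to compound 4 a step of about a 2.7-fold higher number from compound 3 to compound 4 (0.42 log units; beyond the scatter) is expected in this assay, because the same change on the smaller core gave a 3.2-fold higher number from compound 1 to compound 2 (0.51 log units; beyond the scatter). Among the measured compounds shown here, the larger core of compound 3 might carry the change differently, and only one example of the change is known, so the expectation is held loosely. Compound 4 is therefore estimated to give about 800 nM in this assay. Compound 4 is expected to fall somewhere between 350 nM and 1900 nM.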

Compound 4, inhibition constant: 446 nM
Estimate against measurement, compound 4: 1.8-fold (0.25 log units) above, and the stated range covers the measured number.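

In this series, putting isobutyl in place of isopropyl on an oxygen on an aromatic ring in this assay gave a 1.5-fold higher number from compound 3 to compound 4 (0.17 log units; within the scatter), a step small enough to be ordinary repeat-to-repeat variation. Set beside the earlier step on the smaller core, the result gives no sign that the two cores carry this change differently: the same change on two cores in this assay, a 3.2-fold higher number (0.51 log units; beyond the scatter) from compound 1 to compound 2 and a 1.5-fold higher number (0.17 log units; within the scatter) from compound 3 to compound 4, 2.2-fold (0.34 log units) apart, within the scatter of two such steps. Going by these compounds alone, this does not prove that the change carries over unchanged: only two pairs are available, one step lies beyond the scatter and the other within it, so the data cannot settle whether the swap has a real effect on the larger core, and they give no reason for either step.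

The compounds shown leave open how other groups on that oxygen would behave, such as a longer chain like n-hexyl, a cyclopropylmethyl group or a chain ending in an amine, and whether any of them would follow the same pattern on both cores. They also leave open which of the many differences between the larger core and the smaller one accounts for the gap between their values.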